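Benzyl to 4-methoxyphenyl on the aromatic nitrogen

The source may report more compounds than this note shows. Statements on the series, on what has been measured and on what is new or still open speak of the compounds shown alone.

Compound 1 (`COc1cc(-c2nccn2CC(C)C)cc(OC)c1OC`) gives > 100000 nM in a functional assay on MDA-MB-231 cells (Homo sapiens) for antiproliferative activity, read by MTT assay, with a stated time of 72 h (on this read-out lower numbers stand for stronger inhibition and higher numbers for weaker inhibition), as a limit of the assay. Compound 2 (`COc1cc(-c2nccn2Cc2ccccc2)cc(OC)c1OC`) gives > 100000 nM as a limit too. Compound 2 therefore stands at the limit of > 100000 nM in this assay, at which 2 of the 3 values shown sit, and has no number. For the measured compounds named here, the one step between measured compounds is a step that the two limits leave unreadable from compound 1 to compound 2 and it offers no size to carry forward.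

Compound 4 (`COc1ccc(-n2ccnc2-c2cc(OC)c(OC)c(OC)c2)cc1`) replaces benzyl with 4-methoxyphenyl on an aromatic nitrogen: 4-methoxyphenyl in place of benzyl on an aromatic nitrogen is the change. Going by the values given here, no measured step covers this replacement. Among the compounds with values here, the nearest guide is compound 3 (`COc1cc(-c2nccn2-c2ccc3cc[nH]c3c2)cc(OC)c1OC`) at 7500 nM in this assay as the only compound with a number, and like compound 4 it has an aromatic ring bound directly to that nitrogen.

On that basis the expected change is an at least 5.0-fold lower number from compound 2 to compound 4 (0.69 log units; beyond the scatter) and its expected direction is toward stronger inhibition, with its size poorly fixed. In this assay the estimated value for compound 4 is 20000 nM with an expected range from 4000 nM to 100000 nM and a real chance of another limit.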

Compound 4, half-maximal inhibitory concentration: 2700 nM
For compound 4 the middle estimate is 7.4-fold (0.87 log units) above the measured one, and the stated range ends above it.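

In this assay, replacing benzyl with 4-methoxyphenyl on the aromatic nitrogen gives an at least 37-fold lower number from compound 2 to compound 4 (1.56 log units; beyond the scatter), and replacing isobutyl there gives an at least 37-fold lower number from compound 1 to compound 4 (1.56 log units; beyond the scatter). With compound 3 at 7500 nM and compound 4 at 2700 nM, both compounds with an aromatic ring bound directly to that nitrogen carry a number, while the two with a saturated chain carbon there do not. Both steps remain bounds rather than sizes because each starts from a limit: the limit of > 100000 nM in this assay, at which 2 of the 4 values shown sit.

Going by these compounds, how an unsubstituted phenyl on this nitrogen would compare with 4-methoxyphenyl remains open, and so does the part played by the methoxy group itself. Also open, on these data alone, is whether a 4-aminophenyl or a 4-carboxyphenyl group would hold the number reached by compound 4 2700 nM.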